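An Isopropoxy Group Added to Compound 1

The compounds below may be only part of what the source reports. "The series", "measured", "known", "first", "only" and "open" are said of these compounds alone.

Measured compounds:
- Compound 1 `Nc1nc(NCc2ccccc2)nc(-c2ccccc2CO)n1` gives, in a functional assay on cells for positive allosteric modulation of G-protein coupled receptor 68 (Homo sapiens), read by a luciferase reporter and cAMP accumulation, with a stated time of 30 min, at pH 6.8 and pH 8.3, in the presence of a further agent that is not named here (a higher number here means a more potent compound, by a factor of ten per unit of this negative logarithm, a lower number a less potent compound), 4.35
- Compound 2 `CCNc1nc(NCc2ccccc2)nc(-c2ccccc2CO)n1` gives in this assay 4.63
- Compound 3 `NCc1ccccc1-c1nc(N)nc(NCc2ccccc2)n1` gives in this assay 3.86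

Compound 1 stands second highest of the three numbers. Its nearest neighbour is compound 2, a change of a number 0.28 log units higher from compound 1 to compound 2 (within the scatter) that adds an ethyl group on a ring nitrogen and stays within the scatter. Compound 3 differs by a number 0.49 log units lower from compound 1 to compound 3 (beyond the scatter), a modest loss that goes beyond the scatter.

Compound 4 `CC(C)Oc1ccc(-c2nc(N)nc(NCc3ccccc3)n2)c(CO)c1` carries the change (isopropoxy in place of hydrogen on an aromatic carbon). Neither measured step touches the same place: one alters a nitrogen substituent, the other swaps hydroxymethyl for aminomethyl. Going by the values given here, no measured step therefore bears directly on this change, and the spread of the three numbers is small. The step to compound 4 is expected to be a number 0.15 log units higher from compound 1 to compound 4 (within the scatter), with no clear direction beyond the scatter. Compound 4 is estimated at 4.5, within a range from 3.9 to 5.1.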

Compound 4, negative logarithm of the antagonist equilibrium constant: 4.91
Estimate against measurement, compound 4: 0.41 log units below; low and high end bracket the measured number.
By their numbers in this assay, from the lowest: compound 3; then compounds 1, 2 and 4 (each within the scatter of the next, the first and the last beyond it).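

In this assay this aromatic carbon, para to a large group and meta to a hydroxymethyl group, takes isopropoxy with a gain: the change gives a number 0.56 log units higher from compound 1 to compound 4 (beyond the scatter) and so adds 4 heavy atoms without a loss. It is the only step shown that raises the number beyond the scatter, whereas the ethyl change gives a number 0.28 log units higher from compound 1 to compound 2 (within the scatter) and the amino change gives a number 0.49 log units lower from compound 1 to compound 3 (beyond the scatter) in the downward direction. Nothing measured here says why the number rises.

The compounds shown leave open whether methoxy, a longer chain such as butoxy, or a chlorine atom on this same carbon would give a similar number. They also leave open what a single compound would give if it carried both the isopropoxy of compound 4 and the ethyl of compound 2.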